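From a Decyl Chain Back to a Methoxyphenyl Ring

This account rests on a few compounds, and the source may have more. Where it says the series, first, only, none or still open, it means among the compounds named here.

Of the compounds shown here, three sharing one core have been measured. Compound 1 `CC(C)(C)OC(=O)N1CCN(C(=S)SCc2cn(C[C@H](O)[C@H]3OC(=O)C(OCc4ccccc4)=C3OCc3ccccc3)nn2)CC1` gives 60 nM in an ADME assay on HFF cells (Homo sapiens) for cytotoxicity, read by MTT assay, with a stated time of 72 h; on this read-out higher numbers stand for weaker inhibition and lower numbers for stronger inhibition. Compound 2 `COc1ccccc1-c1cn(C[C@H](O)[C@H]2OC(=O)C(OCc3ccccc3)=C2OCc2ccccc2)nn1` gives 50 nM in this assay. Compound 3 `CCCCCCCCCCc1cn(C[C@H](O)[C@H]2OC(=O)C(OCc3ccccc3)=C2OCc2ccccc2)nn1` is reported in this assay only as a limit, > 100000 nM, so no number is known for it. Compound 3 therefore sits at the limit of > 100000 nM in this assay, at which 1 of the 3 values shown sits, apart from compound 1 and compound 2. For the measured compounds named here, the single step measured between neighbours is an at least 2000-fold higher number from compound 2 to compound 3 (3.30 log units; beyond the scatter).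

Compound 4 `COc1ccc(-c2cn(C[C@H](O)[C@H]3OC(=O)C(OCc4ccccc4)=C3OCc3ccccc3)nn2)cc1` differs from compound 3 by 4-methoxyphenyl in place of decyl on an aromatic carbon. This runs opposite to the kind of change seen in an at least 2000-fold higher number from compound 2 to compound 3 (3.30 log units; beyond the scatter), a methoxyphenyl group again standing in place of decyl, so a large step down in this assay is expected, with compound 2 as the nearest measured guide. Compound 4 is estimated at 60 nM, between 15 nM and 300 nM. Such a value would mean an expected step of an at least 1600-fold lower number from compound 3 to compound 4 (3.22 log units; beyond the scatter).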

Compound 4, half-maximal inhibitory concentration: < 10 nM
Compound 4 was reported as a limit; the forecaster's own chance of this, stated with the estimate: 5%; at least 6.0-fold (0.77 log units) between middle value and limit.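

For the compounds shown here, on this aromatic carbon of the shared core, the earlier compounds had set only a 2-methoxyphenyl group against a decyl chain in this assay, and the new result shows that the wide gap is not tied to that one methoxyphenyl group, with an at least 10000-fold lower number from compound 3 to compound 4 (4.00 log units; beyond the scatter). It also shows that the two methoxyphenyl groups are not interchangeable here, with an at least 5.0-fold lower number from compound 2 to compound 4 (0.69 log units; beyond the scatter). Compound 4 is reported only as a limit, so both steps give a minimum size and not an exact one: the limit of < 10 nM in this assay, at which 1 of the 4 values shown sits.

The compounds shown leave open where an unsubstituted phenyl ring, a hydroxyl group in place of the methoxy group, or a shorter chain such as butyl would fall in this assay. They also leave open how far compound 3 and compound 4 truly lie apart.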